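A few compounds are considered here, and "the series" means these few. Any claim that something is new, unique, unknown or untested is made for them only; others in the source may bear on it.

Compound 1, `CC(C)=CCC1=C(OCc2cn(-c3ccccc3)nn2)C(=O)c2ccccc2C1=O`, in an ADME assay on HepG2 cells (Homo sapiens) for cytotoxicity, read by MTT assay, with a stated time of 24 h (a higher number here means that more compound is tolerated, a lower number that less compound is tolerated), gives 100000 nM.
Compound 2, `CC(C)=CCC1=C(OCc2cn(-c3ccc(C#N)cc3)nn2)C(=O)c2ccccc2C1=O`, in this assay gives 707000 nM.

For the measured compounds named here, compound 2 stands highest of the two numbers in this assay; its nearest neighbour is compound 1, and the one step known, a 7.1-fold higher number from compound 1 to compound 2 (0.85 log units; beyond the scatter), is modest. Compound 3, `CC(C)=CCC1=C(OCc2cn(-c3ccc([N+](=O)[O-])cc3)nn2)C(=O)c2ccccc2C1=O`, differs from compound 2 by nitro in place of cyano on an aromatic carbon. Going by the values given here, no measured step covers this exchange; the only step at this position was the modest one from compound 1 to compound 2, so a small step, or none beyond the scatter, is expected in this assay. Compound 3 is therefore estimated at 500000 nM, between 150000 nM and 1500000 nM, a step of a 1.4-fold lower number from compound 2 to compound 3 (0.15 log units; within the scatter).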

Compound 3, half-maximal cytotoxic concentration: 540000 nM
Beside the measured number, compound 3's estimate is 1.1-fold (0.03 log units) below it, and the stated range covers the measured number.
By their numbers in this assay, from the lowest: compound 1; then compounds 3 and 2 (each within the scatter of the next).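

In this assay the exchange of 4-cyanophenyl for 4-nitrophenyl gives a 1.3-fold lower number from compound 2 to compound 3 (0.12 log units; within the scatter) and so does not separate these two groups at this position. With nitro in place of hydrogen on the same aromatic carbon there is a 5.4-fold higher number from compound 1 to compound 3 (0.73 log units; beyond the scatter) and thus the shift seen with cyano is not confined to that one group. No measurement available here explains these numbers. As far as these compounds go, whether an amine or a carboxylic acid on this aromatic carbon would stay with compounds 2 and 3 or return to compound 1 remains open.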